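The source may hold more compounds than are shown below. What is called first, only, known or untested is meant among the compounds shown, and "the series" means these compounds.

Within the data shown here, in an ADME assay on a cell-free system (plasma, Homo sapiens) for protein binding, read by LC-MS, with a stated time of 5 h, tested at 10 uM, compound 1 `O=[N+]([O-])c1ccc2c(ccn2-c2ccc(O[C@H]3O[C@H](CO)[C@@H](O)[C@H](O)[C@@H]3O)c(Cl)c2)c1` gives 99% and has the lower unbound fraction of the two compounds measured so far. Among the measured compounds shown here, in the same assay, this assay, compound 2 `O=[N+]([O-])c1ccc2c(ccn2-c2ccc(O[C@H]3O[C@H](CO)[C@@H](O)[C@H](O)[C@@H]3O)c(F)c2)c1` gives 95% and carries fluoro in place of chloro on an aromatic carbon, a change that amounts to a 5.0-fold higher unbound fraction from compound 1 to compound 2 (0.70 log units; beyond the scatter) as the only measured step. Compound 3 `O=C(O)c1ccc2c(ccn2-c2ccc(O[C@H]3O[C@H](CO)[C@@H](O)[C@H](O)[C@@H]3O)c(Cl)c2)c1` keeps the chloro of compound 1 but differs elsewhere, with carboxy in place of nitro on an aromatic carbon. This change sits on a six-membered aromatic ring of carbon only, part of a fused or bridged system of two rings. For the measured compounds named here, the measured step swaps a different group, so it serves only as a rough gauge of size, and no measured compound carries carboxy. Since compound 1 stands at 99% with the lower unbound fraction, movement toward more free compound seems likelier. The expected change, a 4.0-fold higher unbound fraction from compound 1 to compound 3 (0.60 log units; beyond the scatter), is estimated to be similar in size to the measured step. For compound 3 the estimated value is 96% with an expected range from 88% to 99.2% in this assay's read-out.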

Compound 3, plasma protein binding: 93%
Compound 3: the middle estimate sits 1.8-fold (0.24 log units) (unbound fraction) below what was measured; the measured number falls inside the stated range.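

The step a 7.0-fold higher unbound fraction from compound 1 to compound 3 (0.85 log units; beyond the scatter) shows that in this assay the read-out responds not only to the halogen but also at a second place in the molecule, the aromatic carbon of the six-membered ring that is meta to a fused ring and para to a fused ring. Carboxy and nitro have the same number of heavy atoms but differ in their hydrogen-bond donors and acceptors, and this exchange, like the step a 5.0-fold higher unbound fraction from compound 1 to compound 2 (0.70 log units; beyond the scatter), lies beyond the scatter, so two separate single changes to compound 1 each leave more of the compound free. The data offer no measurement that accounts for the shift seen on replacing nitro with carboxy.

Whether fluoro and carboxy in one molecule would combine their steps remains open, as no compound shown carries both. Going by these compounds, it is equally open how a nitrile, an amide or an amine on the same aromatic carbon would compare with carboxy and nitro, and how far the read-out depends on the sugar part, which stays the same in all three compounds.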